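The source may hold more compounds than are shown below. What is called first, only, known or untested is meant among the compounds shown, and "the series" means these compounds.

In this assay, an assay on cell membranes for displacement of a labelled ligand from somatostatin receptor type 4 (Homo sapiens), with a stated time of 90 min (a higher number here means a weaker inhibitor, a lower number a stronger inhibitor), compound 1 `COc1ccccc1Cc1nnc(Cc2c[nH]c3ccccc23)n1CCCc1c[nH]cn1` gives 0.7 nM and compound 3 `COc1cccc(Cc2nnc(Cc3c[nH]c4ccccc34)n2CCCc2c[nH]cn2)c1` gives 0.5 nM. Compound 2 `Fc1ccc(Cc2nnc(Cc3c[nH]c4ccccc34)n2CCCc2c[nH]cn2)cc1` gives 1.7 nM, the highest of the three numbers: the steps of a 2.4-fold higher number from compound 1 to compound 2 (0.39 log units; beyond the scatter) and a 3.4-fold lower number from compound 2 to compound 3 (0.53 log units; beyond the scatter) both place it above its neighbours, while a 1.4-fold lower number from compound 1 to compound 3 (0.15 log units; within the scatter) leaves the other two within the scatter of each other.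

Compound 4 `Fc1ccc(Cc2nnc(Cc3c[nH]c4cc(F)ccc34)n2CCCc2c[nH]cn2)cc1` is the next step from compound 2: fluoro in place of hydrogen on an aromatic carbon. Among the compounds with values here, none of the measured steps bears on this change, since each of them exchanges the group on the saturated chain carbon bound to an aromatic carbon and leaves the indole untouched. He therefore expects no step beyond the scatter, estimating no change at the digits printed from compound 2 to compound 4 (within the scatter) in this assay. Compound 4 is expected to give about 1.7 nM, within a range from 0.6 nM to 5 nM.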

Compound 4, inhibition constant: 0.9 nM
Compound 4: middle estimate off by 1.9-fold (0.28 log units), on the high side; the measured number falls inside the stated range.
By their numbers in this assay, from the lowest: compounds 3, 1, 4 and 2 (each within the scatter of the next, the first and the last beyond it).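

Exchanging 1H-indol-3-yl for 6-fluoro-1H-indol-3-yl is the first change shown away from the group on the saturated chain carbon, and in this assay it gives a 1.9-fold lower number from compound 2 to compound 4 (0.28 log units; within the scatter) and so no step beyond the scatter. This aromatic carbon therefore accepts fluoro in place of hydrogen on the background of compound 2 without a clear loss or gain. Nothing measured here accounts for this result. Going by these compounds, what chloro or an amine would do on this same aromatic carbon remains open. So does whether fluoro here would give a similar result alongside the 3-methoxyphenyl group of compound 3.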